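A few compounds are considered here, and "the series" means these few. Any claim that something is new, unique, unknown or untested is made for them only; others in the source may bear on it.

Three compounds share one core, an amide linking a pyridine to a tetrazole, and each has been tested in a functional assay on the whole organism with Rattus norvegicus as the target, at a dose of 1 mg/kg by the oral route; on this read-out lower numbers stand for a weaker effect and higher numbers for a stronger effect at the one dose given. Compound 1 `CCc1ccc(-c2cc(Cl)cc(C(=O)Nc3nn[nH]n3)n2)cc1` carries a chloro on the core and a 4-ethylphenyl group, and in this assay compound 1 gives 49%. Compound 2 `COc1cc(C(=O)Nc2nn[nH]n2)nc(-c2ccccc2)c1` carries a methoxy on the core and an unsubstituted phenyl, and compound 2 gives 62%. Compound 3 `COc1cc(C(=O)Nc2nn[nH]n2)nc(-c2ccc(C)cc2)c1` keeps the methoxy but carries a 4-methylphenyl group, and compound 3 gives 42%. The one step among these that differs in a single place shows a number 20 percentage points lower from compound 2 to compound 3 (beyond the scatter). Compound 3 therefore holds the lowest of the three numbers, within the scatter of compound 1 and beyond the scatter below compound 2.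

Compound 4 `CCc1ccc(-c2cc(OC)cc(C(=O)Nc3nn[nH]n3)n2)cc1` differs from compound 3 by methyl in place of hydrogen on a saturated chain carbon bound to an aromatic carbon. Within the data shown here, no measured pair shows a methyl being lengthened to an ethyl; the only related facts are the drop on adding methyl to phenyl and the value of compound 1, which carries the 4-ethylphenyl group together with a different core substituent. On that thin basis the expectation is a step of a number 3 percentage points higher from compound 3 to compound 4 (within the scatter), not beyond the scatter. Compound 4 is estimated at 45%, between 25% and 65%.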

Compound 4, a percentage reported as inhibition, in the whole organism at one dose (the size of the read-out at that dose, not a potency): 43%
For compound 4 the middle estimate is 2 percentage points above the measured one, and the stated range covers the measured number.
By their numbers in this assay, from the lowest: compounds 3, 4 and 1 (each within the scatter of the next); then compound 2.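

In this assay, lengthening methyl to ethyl, the change from 4-methylphenyl to 4-ethylphenyl, gives a number 1 percentage points higher from compound 3 to compound 4 (within the scatter), so this added carbon on the saturated chain has no effect that can be told from the scatter. Ethyl in place of hydrogen on the phenyl gives a number 19 percentage points lower from compound 2 to compound 4 (beyond the scatter), a step beyond the scatter like a number 20 percentage points lower from compound 2 to compound 3 (beyond the scatter), so with the methoxy core both the methyl and the ethyl group read lower than the unsubstituted phenyl, while methoxy in place of chloro on the core, with the 4-ethylphenyl group held constant, gives a number 6 percentage points lower from compound 1 to compound 4 (within the scatter) and cannot be separated from no change. No evidence is available that would explain any of these steps.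

Still open, going by these compounds, is whether a propyl or longer chain at this place would stay level with ethyl, and whether a hydroxyl, an amine or a carboxylic acid there would read closer to the unsubstituted phenyl. On these data alone, it is also open whether the chloro core would show the same difference between a plain phenyl and a 4-ethylphenyl group, and how these compounds would compare at other doses.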